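Pyridinyl to pyrimidinyl sulfonamide in the shared core series

The compounds below may be only part of what the source reports. "The series", "measured", "known", "first", "only" and "open" are said of these compounds alone.

Measured compounds:
compound 1 `Clc1ccc(C(/C=C/c2ccccc2)=N\Nc2nncc3ccccc23)cc1`, 6.9 nM
compound 2 `O=S(=O)(Nc1ccccn1)c1ccc(Nc2nncc3ccccc23)cc1`, 34 nM

In a functional assay on K562 cells (Homo sapiens) for antiproliferative activity, read by sulforhodamine B assay, with a stated time of 72 h (a lower number here means a stronger inhibitor, a higher number a weaker inhibitor), compound 2 gives 34 nM, the higher of the two numbers; compound 1 gives 6.9 nM, a gap beyond the scatter. Compound 3 `O=S(=O)(Nc1ncccn1)c1ccc(Nc2nncc3ccccc23)cc1` differs from compound 2 only by pyrimidin-2-yl in place of pyridin-2-yl on a sulfonamide nitrogen. Among the measured compounds shown here, no measured pair shows such a change, so the step from compound 2 to compound 3 in this assay is expected to be small, in no set direction, and likely within the scatter. Compound 3 is therefore estimated at 40 nM, range 12 nM to 130 nM, meaning an expected 1.2-fold higher number from compound 2 to compound 3 (0.07 log units; within the scatter).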

Compound 3, half-maximal inhibitory concentration: 43 nM
The estimate for compound 3 lay 1.1-fold (0.03 log units) below the measured number; the range from low to high includes it.
By their numbers in this assay, from the lowest: compound 1; then compounds 2 and 3 (each within the scatter of the next).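

In this assay, pyrimidin-2-yl in place of pyridin-2-yl on a sulfonamide nitrogen gives a 1.3-fold higher number from compound 2 to compound 3 (0.10 log units; within the scatter) as the first step read at this position. This exchange of a six-membered aromatic ring with 1 hetero atom for one with 2 hetero atoms therefore leaves the number within the scatter in this matched pair. No measured property of these groups is available to account for the result.

This single step does not show whether the sulfonamide nitrogen tolerates other groups, such as a methyl, a morpholine or a carboxylic acid chain. From the compounds shown here alone, whether the flat response extends to other aromatic rings, such as thiazol-2-yl, also remains open.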